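The source may hold more compounds than are shown below. What is called first, only, known or untested is meant among the compounds shown, and "the series" means these compounds.

Measured so far in an ADME assay on KB cells (Homo sapiens) for cytotoxicity; on this read-out lower numbers stand for an effect already at smaller amounts and higher numbers for an effect only at larger amounts of compound:
- compound 1 `COC(=O)N1[C@@H]2C=C[C@@](OC)(C(=O)c3c2cc(OC)c(OC)c3OCc2ccccc2)N1C(=O)OC` gives > 300 ug/mL
- compound 2 `COc1cc2c(c(OC)c1OC)C(=O)[C@]1(OC)C=C[C@H]2N(C(=O)OCC(C)C)N1C(=O)OCC(C)C` gives > 300 ug/mL
- compound 3 `CCCOc1c(OC)c(OC)cc2c1C(=O)[C@]1(OC)C=C[C@H]2N(C(=O)OCC)N1C(=O)OCC` gives > 300 ug/mL

Each of these entries is a limit of the assay and not a number. Compound 1 therefore has no exact position in the series, only a limit of > 300 ug/mL. The set as a whole shows (the limit of > 300 ug/mL in this assay, at which 3 of the 3 values shown sit). Among the compounds with values here, with no exact values and no single-place change among the measured compounds, the series offers no measured step to work from.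

Next in line is compound 4 `COC(=O)N1[C@@H]2C=C[C@@](OC)(C(=O)c3c2cc(OC)c(OC)c3OCc2ccccc2F)N1C(=O)OC`, which keeps the core of compound 1 and changes only the benzyloxy group to (2-fluorobenzyl)oxy. This is fluoro in place of hydrogen on an aromatic carbon, ortho to a large group: fluoro in place of hydrogen on an aromatic carbon.

In this assay, no step beyond the usual scatter is expected, and no direction is favoured. This expectation rests on compound 1, with its limit of > 300 ug/mL. The expected size of the move a number no higher from compound 1 to compound 4 (the limit leaves the size open) is estimated to be nil. For compound 4 the estimated value is 300 ug/mL, with an expected range of 100 ug/mL to 500 ug/mL, and a report as a limit is the likelier outcome.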

Compound 4, concentration for half-maximal effect: 137 ug/mL
Compound 4: middle estimate off by 2.2-fold (0.34 log units), on the high side; the measured number falls inside the stated range.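

The fluoro in place of hydrogen on an aromatic carbon, ortho to a large group, gives the series its first exact value in this assay, and the step can be read in one direction: an at least 2.1-fold lower number from compound 1 to compound 4 (0.34 log units; beyond the scatter). Compound 1 gives > 300 ug/mL, which is a limit of the assay and not a number, so the step has a lower bound on its size and no exact size. Within the benzyloxy position of this core, then, the change from benzyloxy to (2-fluorobenzyl)oxy is enough on its own to bring a compound off the value at which the rest of the set sits: the limit of > 300 ug/mL in this assay, at which 3 of the 4 values shown sit.

Within the data shown here, the single pair leaves open whether this step is particular to fluoro or whether chloro, methyl, methoxy or an amine on the same aromatic ring would move the number in the same way. It also leaves open whether fluoro at another place on that ring would do the same, and whether the step would carry over to the propoxy series of compound 3.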